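This account rests on a few compounds, and the source may have more. Where it says the series, first, only, none or still open, it means among the compounds named here.

Of the compounds shown here, three sharing one core have been tested in a functional assay on MDA-MB-231 cells (Homo sapiens) for inhibition, read by MTT assay, with stated times of 18 h and 4 h; on this read-out higher numbers stand for weaker inhibition and lower numbers for stronger inhibition. Compound 3 `CCCCCCCCCCOP(=O)(O)OCCSC(=S)N1CCCCC1` gives 24600 nM. Compound 1 `CCCCCCCCOP(=O)(O)OCCSC(=S)N1CCCCC1` differs from compound 3 by hydrogen in place of ethyl on a saturated chain carbon, eight bonds along the chain from an oxygen on an unsaturated carbon, and in this assay compound 1 gives 11900 nM, so that a 2.1-fold lower number from compound 3 to compound 1 (0.32 log units; beyond the scatter). Compound 2 `CCCCCCCCOP(=O)(O)OCCSC(=S)N1CCCCCC1` carries azepan-1-yl in place of piperidin-1-yl on the thiocarbonyl carbon, and in this assay compound 2 gives 27000 nM, which means a 2.3-fold higher number from compound 1 to compound 2 (0.36 log units; beyond the scatter). The difference between the cores of compound 2 and compound 3 is not broken down here.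

Compound 4 `CCCCCCOP(=O)(O)OCCSC(=S)N1CCCCCC1` has not yet been measured; it differs from compound 2 by hydrogen in place of ethyl on a saturated chain carbon, six bonds along the chain from an oxygen on an unsaturated carbon. Going by the values given here, this is the same kind of change as the one from compound 3 to compound 1, but not the same change: there the place was eight bonds along the chain from an oxygen on an unsaturated carbon, here it is six bonds along the chain from such an oxygen. Because the earlier step read a 2.1-fold lower number from compound 3 to compound 1 (0.32 log units; beyond the scatter), a step of similar size is expected from compound 2 to compound 4 in this assay, namely a 2.1-fold lower number from compound 2 to compound 4 (0.32 log units; beyond the scatter). Compound 4 is accordingly estimated at 13000 nM, expected to fall between 6000 nM and 30000 nM.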

Compound 4, half-maximal inhibitory concentration: 17200 nM
Estimate against measurement, compound 4: 1.3-fold (0.12 log units) below, within the range that was stated.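

In this assay, hydrogen in place of ethyl on a saturated chain carbon gives a 1.6-fold lower number from compound 2 to compound 4 (0.20 log units; within the scatter), and the two readings of this change on different cores agree: the same change on two cores in this assay, a 2.1-fold lower number (0.32 log units; beyond the scatter) from compound 3 to compound 1 and a 1.6-fold lower number (0.20 log units; within the scatter) from compound 2 to compound 4, 1.3-fold (0.12 log units) apart, within the scatter of two such steps Taken alone, however, the new step lies within the usual scatter, so compound 2 and compound 4 cannot be told apart by this pair of values. The agreement therefore shows only that nothing here speaks against carrying the change from the piperidin-1-yl compounds to the azepan-1-yl compounds; it rests on two pairs, with the change sitting at a different place along the chain in each, and it gives no general rule for other cores or chain lengths.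

The compounds shown leave open how a decyl chain would read on the core of compound 2, and how a butyl chain would read on either core. They also leave open whether the same change would hold with a different amine on the thiocarbonyl carbon, such as pyrrolidin-1-yl.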